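Two Chlorines Enter Where a Propyl Chain Leaves

The compounds below may be only part of what the source reports. "The series", "measured", "known", "first", "only" and "open" are said of these compounds alone.

Measured so far in a functional assay on CHO cells with adenosine receptor A1 (Homo sapiens) as the target, read by cAMP accumulation and immunoassay, with a stated time of 6 min, tested at 0.01 uM; on this read-out higher numbers stand for a weaker effect at the one concentration tested and lower numbers for a stronger effect:
- compound 1, `Nc1scc(CN2CCN(c3cccc(C(F)(F)F)c3)CC2)c1C(=O)c1ccc(Cl)cc1`: -8.2%
- compound 2, `Nc1scc(CN2CCN(CCCc3ccc(Cl)cc3)CC2)c1C(=O)c1ccc(Cl)cc1`: 0%

Of these two numbers, compound 2 holds the higher one, yet the step of a number 8.2 percentage points higher from compound 1 to compound 2 (within the scatter) lies within the scatter, so the two compounds cannot be told apart on this read-out. Compound 3, `Nc1scc(CN2CCN(c3cc(Cl)ccc3Cl)CC2)c1C(=O)c1ccc(Cl)cc1`, is not yet measured. It differs from compound 2 in one place: 2,5-dichlorophenyl in place of 3-(4-chlorophenyl)propyl on an amine nitrogen in a ring. For the measured compounds named here, the only step available that bears on this exchange is the one between compound 1 and compound 2, where a six-membered aromatic group gave way to a three-carbon chain on the same ring nitrogen and the number moved only within the scatter. Putting an aromatic group back in that position is therefore expected to give a step of a number 4 percentage points lower from compound 2 to compound 3 (within the scatter), that is, nothing beyond the scatter. For compound 3 the value in this assay is estimated at -4%, with a range from -20% to 12%.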

Compound 3, a percentage reported as activity, at one concentration (the size of the read-out at that concentration, not a potency): 13%
Estimate against measurement, compound 3: 17 percentage points below, and the stated range ends below it.
By their numbers in this assay, from the lowest: compounds 1 and 2 (each within the scatter of the next); then compound 3.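

In this assay this position on the ring nitrogen now shows a change larger than the scatter: 2,5-dichlorophenyl gives a number 13 percentage points higher from compound 2 to compound 3 (beyond the scatter) and, set against the trifluoromethyl-bearing phenyl group, a number 21.2 percentage points higher from compound 1 to compound 3 (beyond the scatter) as well. Carrying a phenyl group on this nitrogen therefore does not by itself fix the number, since compound 1 and compound 3 both carry one, and what is attached to that phenyl group can shift the effect modestly toward weaker. Nothing available here gives a reason for this shift.

Open, as far as these compounds go, is whether both chlorines are needed, or whether a phenyl group with a single chlorine would read the same. From the compounds shown here alone, a methoxy group on that phenyl ring, or a longer chain on the nitrogen, is equally open, and one concentration says nothing about potency.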